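Pyridinyl ether in place of benzoyl: an estimate

This account rests on a few compounds, and the source may have more. Where it says the series, first, only, none or still open, it means among the compounds named here.

Measured compounds:
Compound 1 `COc1nc(C)c(Nc2nc(Cl)cn([C@H](COC(C)=O)C3CC3)c2=O)cc1C`: 5.3 nM
Compound 2 `COc1nc(C)c(Nc2nc(Cl)cn([C@H](COC(=O)c3ccccc3)C3CC3)c2=O)cc1C`: 1.5 nM
Compound 3 `COc1nc(C)c(Nc2nc(Cl)cn([C@H](COC(=O)Nc3cccc(C#N)c3)C3CC3)c2=O)cc1C`: 1.3 nM

All three were tested in an assay on frontal cortex for displacement of a labelled ligand from corticotropin-releasing factor receptor 1 (Rattus norvegicus), with a stated time of 2 h; on this read-out higher numbers stand for weaker inhibition and lower numbers for stronger inhibition. Compound 2 gives a lower number than compound 1, the step being a 3.5-fold lower number from compound 1 to compound 2 (0.55 log units; beyond the scatter). Compound 2 and compound 3 are within the scatter of each other, as a 1.2-fold lower number from compound 2 to compound 3 (0.06 log units; within the scatter) shows, so no order between them can be claimed.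

Compound 4 `COc1nc(C)c(Nc2nc(Cl)cn([C@H](COc3ccccn3)C3CC3)c2=O)cc1C` has not been measured. It differs from compound 2 as follows: pyridin-2-yl in place of benzoyl on an oxygen on a saturated carbon. For the measured compounds named here, no measured step matches this change; the two steps that bear on it, a 3.5-fold lower number from compound 1 to compound 2 (0.55 log units; beyond the scatter) and a 4.1-fold lower number from compound 1 to compound 3 (0.61 log units; beyond the scatter), both show that an aromatic ring at this end of the molecule gave modestly lower numbers than methyl. Compound 4 keeps an aromatic ring but not the carbonyl, so a step roughly within the scatter is expected, a 1.7-fold higher number from compound 2 to compound 4 (0.22 log units; within the scatter).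

In this assay compound 4 is expected to give about 2.5 nM, with an estimated range from 0.8 nM to 8 nM.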

Compound 4, half-maximal inhibitory concentration: 1.2 nM
Compound 4: middle estimate off by 2.1-fold (0.32 log units), on the high side; the measured number falls inside the stated range.
By their numbers in this assay, from the lowest: compounds 4, 3 and 2 (each within the scatter of the next); then compound 1.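

In this assay the carbonyl on this oxygen proves dispensable: with pyridin-2-yl attached directly to the oxygen, a 1.3-fold lower number from compound 2 to compound 4 (0.10 log units; within the scatter) and a 1.1-fold lower number from compound 3 to compound 4 (0.03 log units; within the scatter) leave compound 4 indistinguishable from the two carbonyl-linked aromatic compounds. The advantage over the acetyl group of compound 1 remains, at a 4.4-fold lower number from compound 1 to compound 4 (0.65 log units; beyond the scatter) in this comparison, so among these four compounds an aromatic ring at this end goes with the lower numbers, whether or not a carbonyl links it. Nothing available explains why these different links give such similar numbers.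

Still open, as far as these compounds go, is whether the ring nitrogen of pyridin-2-yl matters, which a phenyl group on the same oxygen would test. A free hydroxyl or an amine at this end would show whether an aromatic ring is needed at all.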